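A few compounds are considered here, and "the series" means these few. Any claim that something is new, unique, unknown or untested is made for them only; others in the source may bear on it.

Compound 1 `CCc1cc2c(cc1C(=O)c1ccc(C(=O)O)cc1)C(C)(C)CCC2(C)C` carries an ethyl group on the shared core, and in an assay on isolated protein for binding affinity to retinoic acid receptor beta (Homo sapiens) (on this read-out lower numbers stand for tighter binding and higher numbers for weaker binding), compound 1 gives > 1000 nM, which is a limit of the assay and not a number. Compound 2 `CCCc1cc2c(cc1C(=O)c1ccc(C(=O)O)cc1)C(C)(C)CCC2(C)C` has a propyl group in the same position, and in this assay compound 2 gives > 1000 nM, again only a limit. The step that the two limits leave unreadable from compound 1 to compound 2 therefore cannot be sized, because both compounds rest at the limit of > 1000 nM in this assay, at which 3 of the 3 values shown sit. Compound 3 `C=C(c1ccc(C(=O)O)cc1)c1cc2c(cc1C(C)C)C(C)(C)CCC2(C)C` replaces the ketone bridge with an exocyclic methylene and carries an isopropyl group; in this assay compound 3 gives > 1000 nM, once more a limit. Compound 3 thus stands where the other two stand, at the limit of > 1000 nM in this assay, at which 3 of the 3 values shown sit, and no numerical position can be assigned to it.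

Compound 4 `C=C(c1ccc(C(=O)O)cc1)c1cc2c(cc1Br)C(C)(C)CCC2(C)C` differs from compound 3 by bromo in place of isopropyl on an aromatic carbon, ortho to a large group, meta to a fused ring and para to a fused ring. The only step measured among these compounds, a step that the two limits leave unreadable from compound 1 to compound 2, is unreadable, so no measured step bears on this change in a way that sets a size. Compound 4 is therefore expected to remain near the limit, with an estimated step that the limit leaves unreadable from compound 3 to compound 4 in this assay. The estimate for compound 4 is 1500 nM, between 400 nM and 6000 nM.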

Compound 4, dissociation constant: > 1000 nM
Compound 4: a limit, no number; the forecaster's own chance of this, stated with the estimate: 65%; the middle value does not contradict the limit.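

For the compounds shown here, compound 3 and compound 4 both rest at a limit of the assay and not at a number, so the change from isopropyl to bromo gives no step that can be read: the limit of > 1000 nM in this assay, at which 4 of the 4 values shown sit. The compounds shown leave open how tightly any of them binds in this assay and which change on the shared core would give a readable value.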